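Hydroxy in place of amino on compound 2

This account rests on a few compounds, and the source may have more. Where it says the series, first, only, none or still open, it means among the compounds named here.

Measured in a functional assay on MT4 cells (Homo sapiens), read by MTT assay; a lower number here means that less compound is tolerated, a higher number that more compound is tolerated:
compound 1 `C#C[C@]1(CO)O[C@@H](n2cc(C)c(N)nc2=O)C[C@@H]1O` gives 700 nM
compound 2 `C#C[C@]1(CO)O[C@@H](n2cnc3c(N)ncnc32)C[C@@H]1O` gives 11700 nM

Of these two, compound 2 at 11700 nM stands highest, beyond the scatter from compound 1. Compound 3 `C#C[C@]1(CO)O[C@@H](n2cnc3c(O)ncnc32)C[C@@H]1O` carries hydroxy in place of amino on an aromatic carbon and is otherwise the same as compound 2. Among the compounds with values here, no measured pair shows this change, so the expectation has no direct precedent. In this assay a step of a 5.1-fold higher number from compound 2 to compound 3 (0.71 log units; beyond the scatter) is expected, towards a higher number and beyond the scatter. The estimated value for compound 3 is 60000 nM with an expected range of 15000 nM to 200000 nM.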

Compound 3, half-maximal cytotoxic concentration: 216000 nM
The estimate for compound 3 lay 3.6-fold (0.56 log units) below the measured number, outside the stated range (above it).
By their numbers in this assay, from the lowest: compound 1; then compound 2; then compound 3.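

This position is sensitive in this assay: hydroxy in place of amino on this aromatic carbon gives an 18-fold higher number from compound 2 to compound 3 (1.27 log units; beyond the scatter) as a large step, beyond the scatter. The exchange swaps one heavy atom for one heavy atom, and the counts of hydrogen-bond donors and acceptors stay the same, so a large step here needs no change in those counts. Nothing measured at hand accounts for the size of the step. From the compounds shown here alone, whether methoxy or methylamino on this carbon would move the number the same way remains open. So does whether hydroxy in place of amino on the core of compound 1 would give a step of similar size.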